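A Methyl Added on the Chain Carbon of Compound 3

The source may report more compounds than this note shows. Statements on the series, on what has been measured and on what is new or still open speak of the compounds shown alone.

Measured compounds:
compound 1, `CC/C(=N\NC(=S)NC)c1ccc(C)cc1`, 2000 nM
compound 2, `CCNC(=S)N/N=C(\CC)c1ccc(C)cc1`, 1900 nM
compound 3, `Cc1ccc(C(C)NNC(N)=S)cc1`, 8100 nM

Of the compounds shown here, three have been tested in a functional assay on B16 cells (Mus musculus) for inhibition, with a stated time of 3 days; on this read-out higher numbers stand for weaker inhibition and lower numbers for stronger inhibition. Compound 1 `CC/C(=N\NC(=S)NC)c1ccc(C)cc1` gives 2000 nM in this assay, and compound 2 `CCNC(=S)N/N=C(\CC)c1ccc(C)cc1` gives 1900 nM. The two differ by methyl in place of hydrogen on a saturated chain carbon bound to an amide-type nitrogen, and the step of a 1.1-fold lower number from compound 1 to compound 2 (0.02 log units; within the scatter). Compound 3 `Cc1ccc(C(C)NNC(N)=S)cc1` gives 8100 nM in this assay, the highest of the three numbers; its gap to compound 1 and to compound 2 lies beyond the scatter. The difference between the core of compound 3 and the core of compound 1 is not broken down here.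

Compound 4 `CCC(NNC(N)=S)c1ccc(C)cc1` has not yet been measured. It differs from compound 3 by methyl in place of hydrogen on a saturated chain carbon, two bonds along the chain from an amine nitrogen and an aromatic carbon. For the measured compounds named here, this is the same kind of change as the one from compound 1 to compound 2, but not the same: there the methyl enters on a saturated chain carbon bound to an amide-type nitrogen, while here it enters on a saturated chain carbon two bonds along the chain from an amine nitrogen and an aromatic carbon. Going by the values given here, since the only comparable step, a 1.1-fold lower number from compound 1 to compound 2 (0.02 log units; within the scatter), stayed within the scatter, a small step is expected here as well, with the number for compound 4 estimated to lie somewhat under that of compound 3, a step of a 1.6-fold lower number from compound 3 to compound 4 (0.21 log units; within the scatter). Compound 4 is therefore expected to give about 5000 nM in this assay, with a range from 1500 nM to 15000 nM.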

Compound 4, half-maximal inhibitory concentration: 3900 nM
Beside the measured number, compound 4's estimate is 1.3-fold (0.11 log units) above it; the measured number falls inside the stated range.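

In this assay the added methyl brings a 2.1-fold lower number from compound 3 to compound 4 (0.32 log units; beyond the scatter), a modest step, and set beside the earlier step on the other core, the two do not differ: the same change on two cores in this assay, a 1.1-fold lower number (0.02 log units; within the scatter) from compound 1 to compound 2 and a 2.1-fold lower number (0.32 log units; beyond the scatter) from compound 3 to compound 4, 2.0-fold (0.30 log units) apart, within the scatter of two such steps

Within this small set, then, the change can be carried from one core to the other with no gap between the two steps that stands clear of the scatter, although only the newer step lies beyond the scatter by itself. This does not establish a shared size for the step or a general rule for the series: the comparison rests on just two pairs, and the methyl enters on a saturated chain carbon bound to an amide-type nitrogen in one pair, but on a saturated chain carbon two bonds along the chain from an amine nitrogen and an aromatic carbon in the other.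

The compounds shown leave open whether a longer chain, such as propyl, at the place of the methyl to ethyl change in compound 4 would extend the step or reverse it. They also leave open what a hydroxyl group or an amine at that carbon would do in this assay.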